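A Carbamate Swap on the Saturated Ring Carbon

This account rests on a few compounds, and the source may have more. Where it says the series, first, only, none or still open, it means among the compounds named here.

Compound 1, `O=C1C[C@@H]2CCCC[C@@H]2[C@H]1/C=C/c1ccc(-c2cccc(F)c2)cn1`: 1100 nM
Compound 2, `OC1C[C@@H]2CCCC[C@@H]2[C@H]1/C=C/c1ccc(-c2cccc(F)c2)cn1`: 220 nM
Compound 3, `O=C(Nc1ccccc1)OC1C[C@@H]2CCCC[C@@H]2[C@H]1/C=C/c1ccc(-c2cccc(F)c2)cn1`: 360 nM

Of the compounds shown here, three sharing one core have been tested in an assay on cell membranes for displacement of a labelled ligand from proteinase-activated receptor 1 (Homo sapiens), read by scintillation counting, with a stated time of 60 min; on this read-out lower numbers stand for stronger inhibition and higher numbers for weaker inhibition. Compound 3 sits second highest of the three numbers: its nearest neighbour is compound 2, while compound 1 lies furthest away, beyond the scatter. Within the data shown here, the one single-point step, a 1.6-fold higher number from compound 2 to compound 3 (0.21 log units; within the scatter), shows that hanging a phenylcarbamoyl group on the ring oxygen left the number essentially where it was.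

Compound 4, `CCOC(=O)NC1C[C@@H]2CCCC[C@@H]2[C@H]1/C=C/c1ccc(-c2cccc(F)c2)cn1`, carries the change ((ethoxycarbonyl)amino in place of (phenylcarbamoyl)oxy on a saturated ring carbon). Among the measured compounds shown here, no measured step touches this exchange directly; the only step that bears on it is the one from compound 2 to compound 3, which was within the scatter and suggests that what hangs off this ring carbon has so far mattered little. On that basis compound 4 is expected to stay close to compound 3, with the step of a 1.1-fold higher number from compound 3 to compound 4 (0.05 log units; within the scatter) not clearly beyond the scatter, though the loss of the ring leaves room for movement either way. The estimate for compound 4 in this assay is 400 nM, with a range from 150 nM to 1100 nM.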

Compound 4, half-maximal inhibitory concentration: 2000 nM
For compound 4 the middle estimate is 5.0-fold (0.70 log units) below the measured one, and the stated range ends below it.
By their numbers in this assay, from the lowest: compounds 2 and 3 (each within the scatter of the next); then compounds 1 and 4 (each within the scatter of the next).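

In this assay the group on this saturated ring carbon turns out to matter: there is a 5.6-fold higher number from compound 3 to compound 4 (0.74 log units; beyond the scatter) and a 9.1-fold higher number from compound 2 to compound 4 (0.96 log units; beyond the scatter), whereas the earlier exchange of hydroxy for (phenylcarbamoyl)oxy had left the number within the scatter. The position therefore does not accept every group of this kind alike, since (phenylcarbamoyl)oxy and (ethoxycarbonyl)amino have the same hydrogen-bond donor and acceptor counts and no net charge, yet read differently; what separates them is the six-membered aromatic ring that leaves, the smaller heavy-atom count of the group that enters, and a ring carbon now bearing nitrogen rather than oxygen. Nothing available explains why the number rises with this exchange.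

The compounds shown leave open whether the rise follows the linking atom or the lost aromatic ring, as this one exchange alters both at once: (phenoxycarbonyl)amino or (ethylcarbamoyl)oxy on this ring carbon would pull the two apart. They also leave open how a plain amine or a carboxylic acid at this carbon would read in this assay against the hydroxy of compound 2.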